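Para substituent survey on the pyridyl-enamine series

This account rests on a few compounds, and the source may have more. Where it says the series, first, only, none or still open, it means among the compounds named here.

Three compounds carrying a substituent on the phenyl ring have numbers. Compound 1 `C(=C1\CCCN=C1c1cccnc1)\c1ccccc1` gives 850 nM in an assay on membranes from brain for displacement of a labelled ligand from Neuronal acetylcholine receptor; alpha4/beta2 (Rattus norvegicus), with a stated time of 3 h; on this read-out higher numbers stand for weaker inhibition and lower numbers for stronger inhibition. Compound 2 `CCCc1ccc(/C=C2\CCCN=C2c2cccnc2)cc1` gives 890 nM in this assay, and compound 3 `CC(C)(C)Oc1ccc(/C=C2\CCCN=C2c2cccnc2)cc1` gives 2170 nM. Compound 3 stands with the highest number of the three: the step of a 2.6-fold higher number from compound 1 to compound 3 (0.41 log units; beyond the scatter) and the step of a 2.4-fold higher number from compound 2 to compound 3 (0.39 log units; beyond the scatter) are both beyond the scatter, while a 1.0-fold higher number from compound 1 to compound 2 (0.02 log units; within the scatter) is not.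

Compound 4 `CSc1ccc(/C=C2\CCCN=C2c2cccnc2)cc1` differs from compound 3 by methylsulfanyl in place of tert-butoxy on an aromatic carbon. Among the compounds with values here, no measured pair exchanges these two groups, so the two steps that end at compound 3 are the nearest guide: both show that putting tert-butoxy in place of a smaller group raised the number by a modest amount. Taking away tert-butoxy for methylsulfanyl is therefore expected to bring the number down by a step of similar or smaller size, a 2.0-fold lower number from compound 3 to compound 4 (0.30 log units; within the scatter), toward where compound 1 and compound 2 sit. Compound 4 is estimated at 1100 nM, with a range from 450 nM to 2700 nM.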

Compound 4, inhibition constant: 900 nM
For compound 4 the middle estimate is 1.2-fold (0.09 log units) above the measured one; low and high end bracket the measured number.
By their numbers in this assay, from the lowest: compounds 1, 2 and 4 (each within the scatter of the next); then compound 3.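

At this aromatic carbon, the exchange of tert-butoxy for methylsulfanyl can now be read directly in this assay: a 2.4-fold lower number from compound 3 to compound 4 (0.38 log units; beyond the scatter). Methylsulfanyl shows no separation from propyl or hydrogen, with a 1.0-fold higher number from compound 2 to compound 4 (0.00 log units; within the scatter) and a 1.1-fold higher number from compound 1 to compound 4 (0.02 log units; within the scatter), so tert-butoxy is the only one of the four groups that stands apart from the others. Nothing available explains why this group alone differs.

As far as these compounds go, whether a smaller ether such as methoxy or an all-carbon branched group such as tert-butyl would read with compound 3 or with compounds 1, 2 and 4 remains open. How an amine or a carboxylic acid at this aromatic carbon would read is also open, as the four groups shown include neither.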